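Ethoxycarbonyl to isobutoxycarbonyl: working notes toward compound 3

This account rests on a few compounds, and the source may have more. Where it says the series, first, only, none or still open, it means among the compounds named here.

Measured so far:
Compound 1 `COC(=O)N1CCC(Oc2ncnc(Oc3ccc(/C=C4\SC(=O)NC4=O)cc3)c2C)CC1`: 1410 nM in a functional assay on CHO-K1 cells for agonist activity at Glucose-dependent insulinotropic receptor (Homo sapiens), read by cAMP accumulation and immunoassay, with a stated time of 1 h; a higher number here means that more compound is needed for the effect, a lower number that less compound is needed
Compound 2 `CCOC(=O)N1CCC(Oc2ncnc(Oc3ccc(/C=C4\SC(=O)NC4=O)cc3)c2C)CC1`: 157 nM

For the measured compounds named here, compound 2 holds the lower of the two numbers; the single measured step is a 9.0-fold lower number from compound 1 to compound 2 (0.95 log units; beyond the scatter). Compound 3 `Cc1c(Oc2ccc(/C=C3\SC(=O)NC3=O)cc2)ncnc1OC1CCN(C(=O)OCC(C)C)CC1` differs from compound 2 by isopropyl in place of methyl on a saturated chain carbon bound to an oxygen next to a carbonyl group; one bond further out this reads ethoxycarbonyl to isobutoxycarbonyl. Going by the values given here, only that one step speaks to this position, and it ran toward a lower number as the chain grew, so a further but smaller move in the same direction is expected, a 2.0-fold lower number from compound 2 to compound 3 (0.29 log units; within the scatter), with no certainty that the gain continues. Compound 3 is therefore estimated at 80 nM, between 25 nM and 300 nM.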

Compound 3, half-maximal effective concentration: 75.1 nM
Estimate against measurement, compound 3: 1.1-fold (0.03 log units) above; the range from low to high includes it.
By their numbers in this assay, from the lowest: compound 3; then compound 2; then compound 1.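

In this assay, isobutoxycarbonyl extends the fall seen with ethoxycarbonyl: the change gives a 2.1-fold lower number from compound 2 to compound 3 (0.32 log units; beyond the scatter), a smaller step than a 9.0-fold lower number from compound 1 to compound 2 (0.95 log units; beyond the scatter) but still a real one. Across the three compounds, none of which goes against the trend, the number falls as the chain grows, reaching a 19-fold lower number from compound 1 to compound 3 (1.27 log units; beyond the scatter). Nothing available explains this trend.

Still open, as far as these compounds go, is whether a longer chain such as hexyl, or a benzyl group, in place of isobutyl would lower the number further. From the compounds shown here alone, the point at which the trend stops also remains unknown.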